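Bromo for methoxy: an estimate for compound 3

A few compounds are considered here, and "the series" means these few. Any claim that something is new, unique, unknown or untested is made for them only; others in the source may bear on it.

Within the data shown here, compound 1 `COc1ccc(Nc2cc(-c3ccccc3)oc(=O)c2)cc1` is the only compound of the pair with a number in a functional assay on DU-145 cells (Homo sapiens) for cytotoxicity, read by MTT assay, with a stated time of 72 h; a lower number here means that less compound is needed, a higher number that more compound is needed for the effect: compound 1 gives 0.12 uM. Compound 2 `COc1ccc(Nc2cc(C)oc(=O)c2)cc1` returns only a limit, > 30 uM, in this assay. Among the measured compounds shown here, the sole measured step, an at least 250-fold higher number from compound 1 to compound 2 (2.39 log units; beyond the scatter), sits at another position, with the limit of > 30 uM in this assay, at which 1 of the 2 values shown sits, marking compound 2. It does not bear on the change to compound 3 `O=c1cc(Nc2ccc(Br)cc2)cc(-c2ccccc2)o1`, which is bromo in place of methoxy on an aromatic carbon. For the measured compounds named here, no measured step touches the methoxy, so the expectation rests on compound 1 alone and is held near it with a wide range. Compound 3 is estimated at 0.2 uM, with a range from 0.04 uM to 1 uM. The expected step for compound 3 is a 1.7-fold higher number from compound 1 to compound 3 (0.22 log units; within the scatter).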

Compound 3, concentration for half-maximal effect: 0.34 uM
Beside the measured number, compound 3's estimate is 1.7-fold (0.23 log units) below it; the range from low to high includes it.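

Bromo in place of methoxy on this aromatic carbon, para to a large group, gives a 2.8-fold higher number from compound 1 to compound 3 (0.45 log units; beyond the scatter) in this assay, a modest change. The position therefore accepts a group with no hydrogen-bond acceptor and still gives a measured number, unlike the limit that compound 2 returns after its change elsewhere. Nothing shown gives a reason for this step.

As far as these compounds go, whether an amine, a carboxylic acid or a longer chain at this position would stay in the same range remains open. So does whether the change from methoxy to bromo would have a similar size with methyl in place of phenyl.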